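Swapping the Aromatic Group on the Imine Carbon

The source may report more compounds than this note shows. Statements on the series, on what has been measured and on what is new or still open speak of the compounds shown alone.

Compound 1 `O=C(CSc1nnc(-c2ccncc2)o1)N/N=C/c1ccc(Cl)cc1`: 17000 nM in a functional assay on SW 1116 cells (Homo sapiens) for cytotoxicity, read by MTT assay, with a stated time of 48 h; on this read-out lower numbers stand for stronger inhibition and higher numbers for weaker inhibition
Compound 2 `O=C(CSc1nnc(-c2ccncc2)o1)N/N=C/c1cc(Br)cc(Br)c1O`: 8570 nM in this assay

Compound 2 and compound 1 lie within the scatter of each other, as a 2.0-fold lower number from compound 1 to compound 2 (0.30 log units; within the scatter) shows. Compound 3 `COc1cc(/C=N/NC(=O)CSc2nnc(-c3ccncc3)o2)ccc1O` differs from compound 2 by 4-hydroxy-3-methoxyphenyl in place of 3,5-dibromo-2-hydroxyphenyl on a carbon with a double bond to nitrogen. Going by the values given here, no measured step covers this exchange; the only measured step, a 2.0-fold lower number from compound 1 to compound 2 (0.30 log units; within the scatter), concerns a different aromatic group and stayed within the scatter. Accordingly no step beyond the scatter is expected in this assay. Compound 3 is estimated at 12000 nM, with a range from 4000 nM to 40000 nM. The expected step is a 1.4-fold higher number from compound 2 to compound 3 (0.15 log units; within the scatter).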

Compound 3, half-maximal inhibitory concentration: 3590 nM
Estimate against measurement, compound 3: 3.3-fold (0.52 log units) above; the measured number lies below the stated range.
By their numbers in this assay, from the lowest: compound 3; then compounds 2 and 1 (each within the scatter of the next).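

Going by these compounds alone, at the carbon with a double bond to nitrogen, 4-hydroxy-3-methoxyphenyl gives the first changes beyond the scatter in this assay, with a 2.4-fold lower number from compound 2 to compound 3 (0.38 log units; beyond the scatter) and a 4.7-fold lower number from compound 1 to compound 3 (0.68 log units; beyond the scatter) as its steps. The position therefore responds to the aromatic group it carries, although both steps are modest. Nothing available explains this difference.

Whether the hydroxy or the methoxy group alone would account for the change remains open, since the whole aromatic group differs in each step. From the compounds shown here alone, how an amine or a carboxylic acid on that aromatic ring would read here also remains open.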